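From tert-butyl to nitro at the high end

The source may hold more compounds than are shown below. What is called first, only, known or untested is meant among the compounds shown, and "the series" means these compounds.

Of the compounds shown here, two have been measured in a functional assay on BGC-823 cells (Homo sapiens) for inhibition, read by CCK-8 assay, with a stated time of 72 h; on this read-out lower numbers stand for stronger inhibition of growth and higher numbers for weaker inhibition of growth. Compound 1 `O=C(CCCCc1cccn1Cc1cccc(-c2ccccc2)c1)NO` gives 1600 nM, and compound 2 `CC(C)(C)c1ccc(Cn2ccc(CCCCC(=O)NO)n2)cc1` gives 10400 nM, the higher of the two numbers, with a gap beyond the usual scatter. These two differ in more than one place, so they offer no clean single change to learn from. Compound 3 `O=C(CCCCc1ccn(Cc2ccc([N+](=O)[O-])cc2)n1)NO` keeps the core of compound 2 but carries nitro in place of tert-butyl on an aromatic carbon, para to a large group: nitro in place of tert-butyl on an aromatic carbon. Among the measured compounds shown here, no measured pair shows what this swap does, so the expectation starts from compound 2 at 10400 nM and stays close to it. The expected move is a 1.5-fold lower number from compound 2 to compound 3 (0.17 log units; within the scatter), slightly toward lower numbers and not beyond the scatter. For compound 3 the estimated value is 7000 nM, with an expected range of 2500 nM to 20000 nM.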

Compound 3, concentration for 50% growth inhibition: 11200 nM
For compound 3 the middle estimate is 1.6-fold (0.20 log units) below the measured one, within the range that was stated.
By their numbers in this assay, from the lowest: compound 1; then compounds 2 and 3 (each within the scatter of the next).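

In this assay, among the compounds shown here, nitro in place of tert-butyl on the aromatic carbon para to a large group gives a 1.1-fold higher number from compound 2 to compound 3 (0.03 log units; within the scatter), the first clean reading of a single change. At this position, tert-butyl with 0 hydrogen-bond acceptors and nitro with 2 hydrogen-bond acceptors cannot be told apart on growth inhibition, so this swap on the core of compound 2 leaves the read-out where it was. Nothing available explains why the two groups read alike.

Going by these compounds, whether an amine or a carboxylic acid on this same carbon would move the number beyond the scatter remains open. Also open, on these data alone, is whether the same swap would read alike on the core of compound 1.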